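A Fluorobenzyl Swap in a Level Series

The compounds below may be only part of what the source reports. "The series", "measured", "known", "first", "only" and "open" are said of these compounds alone.

In a functional assay on Bel-7402 cells (Homo sapiens) for antiproliferative activity, read by MTT assay, with a stated time of 72 h (on this read-out lower numbers stand for stronger inhibition and higher numbers for weaker inhibition), compound 1 (`C=C1C(=O)O[C@H]2[C@H]1CC/C(COC(=O)Cn1cc(F)c(=O)n(Cc3ccc(F)cc3)c1=O)=C\CC[C@@]1(C)O[C@@H]21`) gives 2730 nM, compound 2 (`C=C1C(=O)O[C@H]2[C@H]1CC/C(COC(=O)Cn1cc(F)c(=O)n(Cc3ccc(Cl)cc3)c1=O)=C\CC[C@@]1(C)O[C@@H]21`) gives 2560 nM and compound 3 (`C=C1C(=O)O[C@H]2[C@H]1CC/C(COC(=O)Cn1cc(F)c(=O)n(Cc3ccc(C(F)(F)F)cc3)c1=O)=C\CC[C@@]1(C)O[C@@H]21`) gives 2250 nM. Compound 3 therefore stands level with the other two, within the scatter of both. Compound 4 (`C=C1C(=O)O[C@H]2[C@H]1CC/C(COC(=O)Cn1cc(F)c(=O)n(Cc3ccccc3F)c1=O)=C\CC[C@@]1(C)O[C@@H]21`) is still unmeasured. Its difference from compound 3 is 2-fluorophenyl in place of 4-(trifluoromethyl)phenyl on a saturated chain carbon bound to an aromatic nitrogen.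

Going by the values given here, three measured steps bear on this change, all of them exchanges on an aromatic carbon: a 1.1-fold lower number from compound 1 to compound 2 (0.03 log units; within the scatter), a 1.2-fold lower number from compound 1 to compound 3 (0.08 log units; within the scatter) and a 1.1-fold lower number from compound 2 to compound 3 (0.06 log units; within the scatter). Each lies within the scatter. Among the compounds with values here, none of the measured compounds carries 2-fluorophenyl, however, so that group remains untested and the range must stay wide. On these small steps, no change beyond the scatter is expected in this assay, and the expected step is a 1.2-fold higher number from compound 3 to compound 4 (0.06 log units; within the scatter). Compound 4 is estimated at 2600 nM, with an expected range from 1500 nM to 4500 nM.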

Compound 4, half-maximal inhibitory concentration: 3770 nM
Compound 4: the middle estimate sits 1.5-fold (0.16 log units) below what was measured; low and high end bracket the measured number.
By their numbers in this assay, from the lowest: compounds 3, 2, 1 and 4 (each within the scatter of the next).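

Measured against each of the three 4-substituted benzyl compounds in this assay, the 2-fluorophenyl group gives a 1.7-fold higher number from compound 3 to compound 4 (0.22 log units; within the scatter) and a 1.5-fold higher number from compound 2 to compound 4 (0.17 log units; within the scatter) and a 1.4-fold higher number from compound 1 to compound 4 (0.14 log units; within the scatter), so all three exchanges on this saturated chain carbon bound to an aromatic nitrogen stay within the scatter. The last of these keeps a single fluorine and changes only its place on the phenyl ring, from 4-fluorophenyl to 2-fluorophenyl, and that exchange too leaves the compounds level, as does the exchange of the whole 4-(trifluoromethyl)phenyl group. No evidence is available that would explain this level result.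

The compounds shown leave open whether a benzyl group with no substituent on its ring, or a longer chain in its place, would stay level with these four. As far as these compounds go, an amine or a carboxylic acid on that ring remains equally open.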